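A few compounds are considered here, and "the series" means these few. Any claim that something is new, unique, unknown or untested is made for them only; others in the source may bear on it.

Compound 2 `COC(=O)c1cc(-n2cc(-c3ccc(OC)cc3)nn2)ccc1O` stands lowest of the two numbers measured in a functional assay on CCRF-CEM cells (Homo sapiens) for inhibition, read by MTT assay, with a stated time of 2 days, tested at 10 uM (on this read-out higher numbers stand for more inhibition at the one concentration tested (going by the name of the read-out) and lower numbers for less inhibition), where compound 2 gives 16%. Compound 1 `COc1ccccc1-c1cn(-c2ccc(O)c(C(=O)Nc3cccc(C(F)(F)F)c3)c2)nn1`, which carries the same (3-(trifluoromethyl)phenyl)amino group on a carbonyl carbon, gives 65% in this assay. Compound 3 `COc1ccc(-c2cn(-c3ccc(O)c(C(=O)Nc4cccc(C(F)(F)F)c4)c3)nn2)cc1` differs from compound 2 by (3-(trifluoromethyl)phenyl)amino in place of methoxy on a carbonyl carbon. Within the data shown here, no measured pair isolates this change, but because compound 1 gives 65% with that group in place, a sizeable rise is expected, estimated as a number 39 percentage points higher from compound 2 to compound 3 (beyond the scatter). Compound 3 is therefore expected to give about 55%, within a range from 30% to 75%.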

Compound 3, a percentage reported as inhibition, at one concentration (the size of the read-out at that concentration, not a potency): 12%
Compound 3: the middle estimate sits 43 percentage points above what was measured; measured number outside the range, below it.
By their numbers in this assay, from the lowest: compounds 3 and 2 (each within the scatter of the next); then compound 1.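

In this assay, (3-(trifluoromethyl)phenyl)amino in place of methoxy on a carbonyl carbon gives a number 4 percentage points lower from compound 2 to compound 3 (within the scatter), so this group brings no gain while 4-methoxyphenyl is present. 4-Methoxyphenyl in place of 2-methoxyphenyl on an aromatic carbon gives a number 53 percentage points lower from compound 1 to compound 3 (beyond the scatter), so among these compounds the high number appears only with 2-methoxyphenyl. Nothing available explains this difference.

The compounds shown leave open how 2-methoxyphenyl behaves with methoxy on the carbonyl carbon. They also leave open what 3-methoxyphenyl or an amine-bearing phenyl group would give on that aromatic carbon.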